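The compounds below may be only part of what the source reports. "The series", "measured", "known", "first", "only" and "open" are said of these compounds alone.

Working notes on the series. In a functional assay with Cavia porcellus as the target (a lower number here means a stronger inhibitor, a higher number a weaker inhibitor), compound 1 `C[C@@]1(C(F)(F)F)CN(c2cccc[n+]2[O-])c2cc(S(=O)(=O)c3ccccc3)ccc2O1` gives 0.28 nM, the lowest of the three numbers in hand. In this assay compound 3 `O=[N+]([O-])c1ccc2c(c1)N(c1cccc[n+]1[O-])CC(C(F)F)(C(F)F)O2` gives 7 nM, and compound 2 `CC1(C)CN(c2cccc[n+]2[O-])c2cc([N+](=O)[O-])ccc2O1` gives 74 nM. Both gaps to compound 1 lie beyond the scatter, compound 3 being the nearer of the two. Among the compounds with values here, no two measured compounds differ in a single place, so no single-change step is on record, and nothing about the configuration at the saturated ring carbon can be read from measured pairs.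

Compound 4 `C[C@]1(C(F)(F)F)CN(c2cccc[n+]2[O-])c2cc(S(=O)(=O)c3ccccc3)ccc2O1` has not been measured. Its relation to compound 1 is this: the two compounds have the same atoms and bonds and differ only in configuration as drawn: 1 of 1 stereo elements differ; a stereocentre at a saturated ring carbon is drawn S in compound 1 and R in compound 4. Within the data shown here, the series holds no measured example of such a change, so direction and size rest on general experience with pairs of this kind: where one configuration gives a low number, the other usually gives a higher one, often by a margin well beyond the scatter, though sometimes the two are close. For compound 4 a weakening is therefore expected, and the step that this expectation means is an 18-fold higher number from compound 1 to compound 4 (1.25 log units; beyond the scatter). Compound 4 is estimated at 5 nM in this assay, with a range from 0.5 nM to 100 nM.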

Compound 4, half-maximal inhibitory concentration: 0.68 nM
Compound 4: middle estimate off by 7.4-fold (0.87 log units), on the high side; the measured number falls inside the stated range.
By their numbers in this assay, from the lowest: compound 1; then compound 4; then compound 3; then compound 2.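

In this assay the series now has its first single-change step, a 2.4-fold higher number from compound 1 to compound 4 (0.39 log units; beyond the scatter), modest in size yet beyond the scatter. The configuration at the saturated ring carbon therefore does register in the number, with S as drawn in compound 1 giving the lower value, but the inversion costs little, and compound 4 still gives 0.68 nM, so a low number at this position is not confined to one configuration. The whole step can be assigned to that single stereocentre, since nothing else changes between the two structures: the fact that compounds 1 and 4 differ only in the configuration as drawn.

Within the data shown here, only this one pair, carrying trifluoromethyl and methyl on that carbon and the phenylsulfonyl group on the core, speaks to configuration, so whether the gap stays this small with a nitro group in place of the phenylsulfonyl group cannot be read. Also open, as far as these compounds go, is what an ethyl chain in place of the methyl, or a nitrile in place of the phenylsulfonyl group, would do to the number and to the gap between the two configurations.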